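A few compounds are considered here, and "the series" means these few. Any claim that something is new, unique, unknown or untested is made for them only; others in the source may bear on it.

Working notes on the series. Two compounds carry numbers in an ADME assay on Caco-2 cells (Homo sapiens) for permeability, in the apical to basolateral direction; on this read-out higher numbers stand for higher permeability and lower numbers for lower permeability. Compound 1, `Cn1cncc1CN1CC(N(CC2CCN(C(=O)c3ccco3)CC2)S(=O)(=O)c2ccccn2)Cc2cc(C#N)ccc21`, gives in this assay a value of 0.5 10^-6 cm/s. Compound 2, `Cn1cnc(S(=O)(=O)N(CCn2cccc2)C2Cc3cc(C#N)ccc3N(Cc3cncn3C)C2)c1`, gives in this assay a value of 0.3 10^-6 cm/s. The two numbers lie within the scatter of each other, so nothing separates compound 1 from compound 2 on this read-out; both sit in the low region of the scale.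

The open point is compound 3, `Cn1cncc1CN1CC(N(CC2CCN(C(=O)CC(F)(F)F)CC2)S(=O)(=O)c2ccccn2)Cc2cc(C#N)ccc21`. It differs from compound 1 in one place: 2,2,2-trifluoroethyl in place of furan-2-yl on a carbonyl carbon. For the measured compounds named here, no measured pair shows this difference, so there is no step to lean on. The expectation rests on the value of compound 1 alone, with the step expected to be a 1.2-fold higher number from compound 1 to compound 3 (0.08 log units; within the scatter), that is, none beyond the scatter. For compound 3 the estimated value in this assay is 0.6 10^-6 cm/s, with the range running from 0.2 10^-6 cm/s to 1.8 10^-6 cm/s.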

Compound 3, apparent permeability: 0.5 10^-6 cm/s
For compound 3 the middle estimate is 1.2-fold (0.08 log units) above the measured one, and the stated range covers the measured number.
By their numbers in this assay, from the lowest: compounds 2, 1 and 3 (each within the scatter of the next).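

In this assay, for the compounds shown here, the pair gives the first step at this position: 2,2,2-trifluoroethyl in place of furan-2-yl on a carbonyl carbon shows no change at the digits printed from compound 1 to compound 3 (within the scatter). Here, an aromatic five-membered ring with one hetero atom and an open-chain group with the same count of heavy atoms give values that cannot be told apart, and compound 3 stays in the low region of the scale. No independent evidence bears on this outcome, so it stands as an observation for this one pair.

On these data alone, whether an amine, a carboxylic acid or a longer chain on this carbonyl carbon would give a step beyond the scatter remains open. With only these two groups shown here, a single pair cannot define how far the read-out depends on the group at this place.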